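The compounds below may be only part of what the source reports. "The series", "measured", "known", "first", "only" and "open" are said of these compounds alone.

Compound 1 `CSc1ccc2c(c1)c(O)c(C(=O)N(C)c1ccccc1)c(=O)n2C` has the highest number of the three measured compounds in a functional assay on the whole organism for inhibition, with Mus musculus as the target, at a dose of 32 mg/kg by the oral route (a lower number here means less inhibition, a higher number more inhibition at the dose given (going by the name of the read-out)), where compound 1 gives 100%. Compound 2 `CN(C(=O)c1c(O)c2cc(S(C)(=O)=O)ccc2n(C)c1=O)c1ccccc1` gives 0%, and compound 3 `CSc1ccc2c(c1)c(Cl)c(C(=O)N(C)c1ccccc1)c(=O)n2C` gives -1%. Both measured steps are large: a number 100 percentage points lower from compound 1 to compound 2 (beyond the scatter) and a number 101 percentage points lower from compound 1 to compound 3 (beyond the scatter). Compound 4 `CSc1ccc2c(c1)c(O)c(C(=O)Nc1ccccc1)c(=O)n2C` differs from compound 1 by hydrogen in place of methyl on an amide-type nitrogen. Going by the values given here, neither measured step touches the amide-type nitrogen; both alter the core, so no step bears directly on this change, and the data give no guide to its size or direction. Since every change tried so far gave a far lower number, a step of a number 45 percentage points lower from compound 1 to compound 4 (beyond the scatter) is estimated, and compound 4 is expected to give 55%, within 0% to 100%.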

Compound 4, a percentage reported as inhibition, in the whole organism at one dose (the size of the read-out at that dose, not a potency): 24%
The estimate for compound 4 lay 31 percentage points above the measured number; the measured number falls inside the stated range.
By their numbers in this assay, from the lowest: compounds 3 and 2 (each within the scatter of the next); then compound 4; then compound 1.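

Going by these compounds alone, the amide-type nitrogen, untouched by the earlier steps, also matters in this assay: hydrogen in place of methyl there gives a number 76 percentage points lower from compound 1 to compound 4 (beyond the scatter). So the number of compound 1 depends on this methyl as well as on the changes to the core, and a single carbon is enough to produce a large step. Nothing available explains this step. From the compounds shown here alone, it remains open whether ethyl or a longer chain on this nitrogen would keep the number of compound 1 or lower it.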